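Replacing the Aminophenyl on the Carbonyl Carbon

This account rests on a few compounds, and the source may have more. Where it says the series, first, only, none or still open, it means among the compounds named here.

Compound 1 `COc1ccc(-c2cc(/C=C/C(=O)c3ccc(N)cc3)[nH]n2)cc1`: 72%
Compound 2 `COc1cc(-c2cc(/C=C/C(=O)c3ccc(N)cc3)[nH]n2)cc(OC)c1OC`: 69%

In a functional assay on SF-539 cells (Homo sapiens) for cytotoxicity, read by sulforhodamine B assay, with a stated time of 48 h, tested at 1 uM (a higher number here means a weaker effect of the compound at the concentration tested, a lower number a stronger effect), compound 1 gives 72% and compound 2 gives 69%. Compound 2 holds the lower of the two numbers, but its gap to compound 1 lies within the scatter, so the two cannot be told apart. Compound 3 `COc1cc(-c2cc(/C=C/C(=O)c3ccc(Cl)c(Cl)c3)[nH]n2)cc(OC)c1OC` differs from compound 2 by 3,4-dichlorophenyl in place of 4-aminophenyl on a carbonyl carbon. Among the compounds with values here, no pair among the measured compounds shows this change, so the step is expected to stay small, likely none beyond the scatter: a number 4 percentage points lower from compound 2 to compound 3 (within the scatter). Compound 3 is therefore estimated to give 65% in this assay, between 45% and 85%.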

Compound 3, a percentage reported as activity, at one concentration (the size of the read-out at that concentration, not a potency): 88%
For compound 3 the middle estimate is 23 percentage points below the measured one; measured number outside the range, above it.
By their numbers in this assay, from the lowest: compounds 2 and 1 (each within the scatter of the next); then compound 3.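

In this assay, 3,4-dichlorophenyl in place of 4-aminophenyl on the carbonyl carbon gives a number 19 percentage points higher from compound 2 to compound 3 (beyond the scatter) and so weakens the effect at the concentration tested. This shows that the group on the carbonyl carbon matters here, which compound 1 and compound 2, sharing 4-aminophenyl, could not show. Nothing available accounts for the step. The compounds shown leave open whether the weaker effect follows from losing the amine or from gaining the two chlorines. A plain phenyl or a 4-chlorophenyl on the same carbon would bear on that.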